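Bromo for fluoro on the 2,4-difluorophenyl group

The source may hold more compounds than are shown below. What is called first, only, known or untested is meant among the compounds shown, and "the series" means these compounds.

In an ADME assay on microsomes from liver (Rattus norvegicus) for metabolic stability (a lower number here means that the compound disappears faster, a higher number that the compound lasts longer), compound 3 `Nc1nc(NCCNc2ncc(-c3ncc[nH]3)c(-c3ccc(F)cc3F)n2)ccc1[N+](=O)[O-]` gives > 0.5 h, which is a limit and not a number. Compound 1 `N#Cc1ccc(-c2nc(NCCNc3ccc([N+](=O)[O-])c(N)n3)ncc2-c2ncc[nH]2)cc1` gives > 0.5 h, also a limit. Compound 2 `FC(F)(F)c1ccc(NCCNc2ncc(-c3ncc[nH]3)c(-c3ccc(Cl)cc3Cl)n2)nc1` gives > 0.5 h, again a limit. The measurements so far all stand at the limit of > 0.5 h in this assay, at which 3 of the 3 values shown sit, so compound 3 cannot be ranked against the other two.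

Compound 4 `Nc1nc(NCCNc2ncc(-c3ncc[nH]3)c(-c3ccc(F)cc3Br)n2)ccc1[N+](=O)[O-]` departs from compound 3 by bromo in place of fluoro on an aromatic carbon, ortho to a large group and meta to a fluoro group. Within the data shown here, the only measured step at this aryl group is a step that the two limits leave unreadable from compound 1 to compound 3, and it gives no size to carry over. Among the measured compounds shown here, no measured step covers this exchange of halogens, so no change beyond the scatter is expected in this assay, and no direction can be assigned. The expected step is a step that the limit leaves unreadable from compound 3 to compound 4. For compound 4 the estimated half-life is 0.8 h, with an expected range of 0.4 h to 1.6 h.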

Compound 4, half-life: > 0.5 h
Compound 4: only a limit was reported (the forecaster's own chance of this, stated with the estimate: 75%); the middle value lies beyond the limit too.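

Compound 4 sits at the same limit as compound 1 and compound 3, so neither the step from compound 3 nor the step from compound 1 to compound 4 can be read: the limit of > 0.5 h in this assay, at which 4 of the 4 values shown sit. Going by these compounds, whether bromo in place of fluoro changes the half-life stays open, as does any ranking of compound 1, compound 2, compound 3 and compound 4 in this assay.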